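A few compounds are considered here, and "the series" means these few. Any claim that something is new, unique, unknown or untested is made for them only; others in the source may bear on it.

Of the compounds shown here, two have been measured in a functional assay on LOX IMVI cells (Homo sapiens) for inhibition, read by sulforhodamine B assay, with a stated time of 48 h; a lower number here means a stronger inhibitor of growth, a higher number a weaker inhibitor of growth. Compound 2 `COc1cc2cc(Oc3ccc(NC(=O)Nc4ccc(Cl)c(C(F)(F)F)c4)cc3)c(C)nc2cc1OC` stands at 4160 nM in this assay, and compound 1 `COc1cc2cc(Oc3ccc(NC(=O)Nc4cccc(C(F)(F)F)c4)cc3)c(C)nc2cc1OC` at 6610 nM; the step of a 1.6-fold lower number from compound 1 to compound 2 (0.20 log units; within the scatter) lies within the scatter, so these two numbers do not set the compounds apart. Compound 3 `COc1cc2cc(Oc3ccc(NC(=O)Nc4ccc(Cl)c(Cl)c4)cc3)c(C)nc2cc1OC` has not yet been measured in this assay. It differs from compound 2 by chloro in place of trifluoromethyl on an aromatic carbon. For the measured compounds named here, the only measured step, a 1.6-fold lower number from compound 1 to compound 2 (0.20 log units; within the scatter), concerns the same ring but a different change, and it stayed within the scatter; no measured pair exchanges a trifluoromethyl for a chloro, so there is no direct precedent for this change. With nothing measured that points to a shift in either direction, the step of a 1.1-fold higher number from compound 2 to compound 3 (0.03 log units; within the scatter) is expected to stay within the scatter, with a wide margin of doubt on both sides. Compound 3 is therefore estimated to give about 4500 nM in this assay, with a likely range from 1800 nM to 11000 nM.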

Compound 3, concentration for total growth inhibition: 14600 nM
Beside the measured number, compound 3's estimate is 3.2-fold (0.51 log units) below it; the whole stated range lies below it.
By their numbers in this assay, from the lowest: compounds 2 and 1 (each within the scatter of the next); then compound 3.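

In this assay, the trifluoromethyl group, which sits ortho to a chloro group on this aromatic ring, proves not to be freely exchangeable: putting chloro in its place gives a 3.5-fold higher number from compound 2 to compound 3 (0.55 log units; beyond the scatter). For the compounds shown here, the earlier compounds showed only that adding a chloro to the ring left the number within the scatter, so this is the first sign that the ring's substituents can change growth inhibition measurably. Compound 3 also stands apart from compound 1, with a 2.2-fold higher number from compound 1 to compound 3 (0.34 log units; beyond the scatter), which makes compound 3 the weakest growth inhibitor of the three, even though the two steps are modest and the compounds shown give no reason for the shift.

Still open is whether the change from trifluoromethyl to chloro would have the same effect on a ring without the second chloro, since only one such exchange is shown. The compounds shown also leave open how this position would respond to other groups, such as methyl, bromo, methoxy, nitrile or an amine, and so whether trifluoromethyl is in any way special there.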